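The source may hold more compounds than are shown below. What is called first, only, known or untested is meant among the compounds shown, and "the series" means these compounds.

Within the data shown here, compound 1 `Cc1ccc2oc(=O)c(C(=O)Nc3ccccc3)cc2c1` is one of two compounds measured in an assay on cells for inhibition of Amine oxidase [flavin-containing] B (Homo sapiens), read by fluorescence and Amplex Red, using microsomes, with a stated time of 15 min (a higher number here means a weaker inhibitor, a lower number a stronger inhibitor), where compound 1 gives 15.3 nM. The other, compound 2 `Cc1ccc2occ(C(=O)Nc3ccccc3)c(=O)c2c1`, carries the same amide and the same methyl on a rearranged core; in this assay compound 2 gives 21.4 nM, which lies within the scatter of compound 1, so the two cannot be told apart on these numbers. Compound 3 `Cc1cccc(NC(=O)c2cc3cc(C)ccc3oc2=O)c1` has not yet been measured. It differs from compound 1 in one place: methyl in place of hydrogen on an aromatic carbon. Among the measured compounds shown here, no measured pair shows what a single methyl on this ring does, so the expectation rests on the small size of the change alone. Compound 3 is therefore expected to land close to compound 1, with the step of a 1.3-fold lower number from compound 1 to compound 3 (0.11 log units; within the scatter) estimated to be no larger than the scatter. The estimate for compound 3 in this assay is 12 nM, within a range from 4 nM to 40 nM.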

Compound 3, half-maximal inhibitory concentration: 7.52 nM
The estimate for compound 3 lay 1.6-fold (0.20 log units) above the measured number; low and high end bracket the measured number.
By their numbers in this assay, from the lowest: compound 3; then compounds 1 and 2 (each within the scatter of the next).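

Among these compounds, the change from phenyl to 3-methylphenyl gives a 2.0-fold lower number from compound 1 to compound 3 (0.31 log units; beyond the scatter) in this assay, the first comparison in this set in which only one place differs. It shows that this ring carbon, meta to a large group, can carry a methyl with no loss of inhibition and a modest gain. Nothing available here bears on why the number falls.

From the compounds shown here alone, it remains open whether a methyl elsewhere on this phenyl ring would give a similar step, or whether an ethyl, a methoxy, a chlorine or an amine on the same carbon would hold or improve the number. Going by these compounds, it is also open whether adding 3-methyl to the phenyl of compound 2, with its rearranged core, would produce a step of the same size.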